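Swapping the aryl group on a quinazoline-type core

A few compounds are considered here, and "the series" means these few. Any claim that something is new, unique, unknown or untested is made for them only; others in the source may bear on it.

Measured so far:
compound 1, `FC(F)(F)c1ccccc1-c1nc(NCC#Cc2cccnc2)c2ccccc2n1`, 8900 nM
compound 2, `FC(F)(F)c1ccccc1-c1nc(NCc2ccc(-c3cccc(Cl)c3)cc2)c2ccccc2n1`, 2700 nM
compound 3, `FC(F)(F)c1cccc(-c2nc(NCc3ccc(-c4cccnc4)cc3)c3ccccc3n2)c1`, "not active" (no number reported)

The three compounds share a common core and were tested in an assay on a protein complex for inhibition of ubiquitin carboxyl-terminal hydrolase 1/WD repeat-containing protein 48 (Homo sapiens), read by fluorescence; a higher number here means a weaker inhibitor, a lower number a stronger inhibitor. Compound 1 gives 8900 nM and compound 2 gives 2700 nM. Compound 3 stands apart: in this assay compound 3 is reported as "not active" (no number reported), and no number accompanies that report, so its place on the scale cannot be given more closely than that it lies beyond what the other two show.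

Compound 4, `Clc1ccccc1-c1nc(NCc2ccc(-c3cccnc3)cc2)c2ccccc2n1`, is not yet measured. It differs from compound 3 in one place: 2-chlorophenyl in place of 3-(trifluoromethyl)phenyl on an aromatic carbon. Among the measured compounds shown here, no measured pair in this set tracks that same change, so the size of the step is open. Since compound 3 yielded no number, the step from compound 3 to compound 4 cannot be stated as a ratio; the expectation rests on the fact that compound 1 and compound 2, both with a number, carry their substituted aryl group in a pattern more like compound 4 than like compound 3. Compound 4 is therefore expected to return a measurable value, roughly in the region of compound 2, estimated at 4000 nM with a range from 1000 nM to 20000 nM.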

Compound 4, half-maximal inhibitory concentration: 2100 nM
For compound 4 the middle estimate is 1.9-fold (0.28 log units) above the measured one, and the stated range covers the measured number.
By their numbers in this assay, from the lowest: compounds 4 and 2 (each within the scatter of the next); then compound 1.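

Among the compounds shown here, compound 3 has no number and compound 4 gives 2100 nM, so no step between them can be read. Nothing shown here offers an explanation for this result. The compounds shown leave open how 2-chlorophenyl in place of 3-(trifluoromethyl)phenyl would act with any other group on the shared core.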